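The source may report more compounds than this note shows. Statements on the series, on what has been measured and on what is new or still open speak of the compounds shown alone.

Measured compounds:
- compound 1, `COc1ccc(C(=O)c2cc(C)ccc2OCC(=O)NNC(=O)c2cc3ccccc3oc2=O)cc1`: 41200 nM in a functional assay on Ehrlich cells (Mus musculus) for cytotoxicity, read by trypan blue exclusion, with a stated time of 48 h; a higher number here means a weaker inhibitor, a lower number a stronger inhibitor
- compound 2, `Cc1ccc(OCC(=O)NNC(=O)c2cc3ccccc3oc2=O)c(C(=O)c2ccccc2)c1`: 86500 nM in this assay

Within the data shown here, compound 1 gives the lower of the two numbers in this assay; its nearest neighbour is compound 2, reached by a 2.1-fold higher number from compound 1 to compound 2 (0.32 log units; beyond the scatter), which is the only step so far.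

Compound 3, `Cc1ccc(OCC(=O)NNC(=O)c2cc3ccccc3oc2=O)c(C(=O)c2ccc(Cl)cc2)c1`, has not been measured in this assay. It differs from compound 1 in one place: chloro in place of methoxy on an aromatic carbon. Among the measured compounds shown here, no measured step covers chloro in place of methoxy directly. For the measured compounds named here, the one step that touches the same position, a 2.1-fold higher number from compound 1 to compound 2 (0.32 log units; beyond the scatter), shows that taking the methoxy away costs a modest amount. Chloro is a different replacement than hydrogen, so that step is only a loose guide; the expected outcome is a number near compound 1 or somewhat higher, with no confident direction beyond the scatter.

Compound 3 is therefore expected at about 55000 nM, within 25000 nM to 120000 nM, which means an expected step of a 1.3-fold higher number from compound 1 to compound 3 (0.13 log units; within the scatter).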

Compound 3, half-maximal inhibitory concentration: 57800 nM
Estimate against measurement, compound 3: 1.1-fold (0.02 log units) below; the measured number falls inside the stated range.
By their numbers in this assay, from the lowest: compounds 1, 3 and 2 (each within the scatter of the next, the first and the last beyond it).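

In this assay chloro at this position cannot be told apart from methoxy (a 1.4-fold higher number from compound 1 to compound 3 (0.15 log units; within the scatter)) or from hydrogen (a 1.5-fold lower number from compound 2 to compound 3 (0.18 log units; within the scatter)). The one separation beyond the scatter at this position is still the modest one between methoxy and hydrogen (a 2.1-fold higher number from compound 1 to compound 2 (0.32 log units; beyond the scatter)), so across these three groups the position has shown only a small spread. No measured property of these compounds is available to account for this pattern.

From the compounds shown here alone, whether an amine, a carboxylic acid or a longer alkoxy chain on this ring would give a larger step remains open. Also open, going by these compounds, is whether changes elsewhere on the shared core would move the number further than any change at this position.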